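The source may report more compounds than this note shows. Statements on the series, on what has been measured and on what is new or still open speak of the compounds shown alone.

Working notes on the series. In a functional assay on NCI-H460 cells (Homo sapiens) for antiproliferative activity (on this read-out higher numbers stand for weaker inhibition of growth and lower numbers for stronger inhibition of growth), compound 1, `Oc1cc(-c2ccc3ccccc3c2)nc2ncccc12`, gives 3800 nM. Compound 2, `Cc1ccnc2nc(-c3cccc4ccccc34)cc(O)c12`, sits at a limit of this assay, < 10 nM, and nothing more than that limit is known of it; (the limit of < 10 nM in this assay, at which 1 of the 3 values shown sits). Compound 3, `Cc1cc(C)c2c(O)cc(-c3cccc4ccccc34)nc2n1`, gives 631 nM in this assay. The difference between the core of compound 1 and the core of compound 2 is not broken down here. From compound 2 to compound 3 the change is methyl in place of hydrogen on an aromatic carbon, and the step is an at least 63-fold higher number from compound 2 to compound 3 (1.80 log units; beyond the scatter). Between the two numbered values, compound 1 stands higher than compound 3, a gap that is beyond the scatter.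

Compound 4, `Cc1cnc2nc(-c3ccc4ccccc4c3)cc(O)c2c1`, is not yet measured in this assay. It differs from compound 1 by methyl in place of hydrogen on an aromatic carbon. This is the same kind of change as from compound 2 to compound 3, but not the same: in compound 3 the methyl enters next to the ring nitrogen and meta to a methyl group, whereas in compound 4 it enters two atoms from the ring nitrogen, and the core of compound 1 carries no methyl group.

For the measured compounds named here, the expectation for compound 4 is a step of a 2.4-fold higher number from compound 1 to compound 4 (0.37 log units; beyond the scatter) in this assay, resting on the one measured instance of this kind of change, the step of an at least 63-fold higher number from compound 2 to compound 3 (1.80 log units; beyond the scatter), with allowance for the different place and for the starting value of compound 1, 3800 nM. The estimate for compound 4 in this assay is 9000 nM, expected to fall between 2500 nM and 40000 nM.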

Compound 4, concentration for 50% growth inhibition: 398 nM
Beside the measured number, compound 4's estimate is 23-fold (1.35 log units) above it; the whole stated range lies above it.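

In this assay, methyl in place of hydrogen on an aromatic carbon gives a 9.5-fold lower number from compound 1 to compound 4 (0.98 log units; beyond the scatter), so this change does not carry from one core to another in this series with a fixed direction or size: the same change on two cores in this assay, an at least 63-fold higher number (1.80 log units; beyond the scatter) from compound 2 to compound 3 and a 9.5-fold lower number (0.98 log units; beyond the scatter) from compound 1 to compound 4, at least 600-fold (2.77 log units) apart, beyond the scatter of two such steps. The comparison also has a soft end, since compound 2 is known only at a limit of this assay and not as a number: the limit of < 10 nM in this assay, at which 1 of the 4 values shown sits. The two steps differ both in the core and in the place of the methyl, and with a single pair for each, these notes cannot separate those two differences or give a cause for the gap.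

Still open, from the compounds shown here alone, is whether an ethyl group, a methoxy group, a chlorine atom or an amine, placed where the methyl sits in compound 4, would also lie on the lower side of compound 1 in this assay, or whether this step is specific to methyl. Also open, going by these compounds, is how methyl behaves at the other aromatic carbons of the core of compound 1, which would show whether the step seen for compound 4 depends on its place.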